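An acetamido analogue of compound 1

This account rests on a few compounds, and the source may have more. Where it says the series, first, only, none or still open, it means among the compounds named here.

In an ADME assay on L929 cells (Mus musculus) for cytotoxicity, read by resazurin assay, with a stated time of 72 h (a higher number here means a weaker inhibitor, a lower number a stronger inhibitor), compound 1 `O=C(/C=C/c1ccc2c(c1)B(O)OC2)c1ccccc1` stands at a limit of the assay, > 10 ug/mL, not at a number. Compound 3 `O=C(/C=C/c1ccc2c(c1)B(O)OC2)c1cccs1` likewise stands at a limit in this assay, > 10 ug/mL. Compound 2 `COCOc1ccccc1C(=O)/C=C/c1ccc2c(c1)B(O)OC2` gives 9.02 ug/mL in this assay. The step of an at least 1.1-fold lower number from compound 1 to compound 2 (0.04 log units; that floor lies within the scatter) is the only readable one, and a step that the two limits leave unreadable from compound 1 to compound 3 gives no size at all. Compound 4 `CC(=O)Nc1ccc(C(=O)/C=C/c2ccc3c(c2)B(O)OC3)cc1` differs from compound 1 by acetamido in place of hydrogen on an aromatic carbon. Neither measured step involves an acetamido group, and the weight of the evidence is the limit of > 10 ug/mL in this assay, at which 2 of the 3 values shown sit. Compound 4 is therefore expected to show no step beyond the scatter, a step that the limit leaves unreadable from compound 1 to compound 4. Compound 4 is estimated at 12 ug/mL in this assay, between 6 ug/mL and 30 ug/mL, most probably reported again as a limit.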

Compound 4, half-maximal inhibitory concentration: > 10 ug/mL
Compound 4: only a limit was reported (the forecaster's own chance of this, stated with the estimate: 70%); the middle value does not contradict the limit.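

Compound 4 gives > 10 ug/mL in this assay, a limit and not a number, and the step from compound 1 to compound 4 cannot be read. The compounds shown leave open whether acetamido in place of hydrogen changes cytotoxicity at all.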